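This account rests on a few compounds, and the source may have more. Where it says the series, first, only, none or still open, it means among the compounds named here.

Measured in a functional assay on M21 cells (Homo sapiens) for antiproliferative activity, read by sulforhodamine B assay, with a stated time of 48 h; on this read-out lower numbers stand for stronger inhibition and higher numbers for weaker inhibition:
Compound 1 `CCCCc1ccc(NS(=O)(=O)c2ccc(N3CCNC3=O)cc2)cc1`: 450 nM
Compound 2 `CCCCCCCc1ccc(NS(=O)(=O)c2ccc(N3CCNC3=O)cc2)cc1`: > 1000 nM
Compound 3 `O=C1NCCN1c1ccc(S(=O)(=O)Nc2ccccc2)cc1`: 200 nM

Compound 3 has the lowest number of the series at 200 nM, and the nearest number belongs to compound 1 at 450 nM. The entry for compound 2, > 1000 nM, is a limit of the assay and not a number.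

Compound 4 `CCCCOc1ccc(NS(=O)(=O)c2ccc(N3CCNC3=O)cc2)cc1` is still unmeasured. It carries butoxy in place of hydrogen on an aromatic carbon, para to a large group: butoxy in place of hydrogen on an aromatic carbon. Within the data shown here, no measured compound has butoxy, so the nearest guide is butyl. Removing a chain lowered the number in two steps: a 2.3-fold lower number from compound 1 to compound 3 (0.35 log units; beyond the scatter) for butyl and an at least 5.0-fold lower number from compound 2 to compound 3 (0.69 log units; beyond the scatter) for heptyl. Lengthening the chain gave an at least 2.2-fold higher number from compound 1 to compound 2 (0.34 log units; beyond the scatter). Read in reverse, the butyl step in compound 1 suggests a modest rise in this assay when butoxy is added. The expected step is a 2.3-fold higher number from compound 3 to compound 4 (0.35 log units; beyond the scatter). Compound 4 is estimated at 450 nM, with an expected range of 170 nM to 1200 nM.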

Compound 4, half-maximal inhibitory concentration: 580 nM
Compound 4: middle estimate off by 1.3-fold (0.11 log units), on the low side; low and high end bracket the measured number.
By their numbers in this assay, from the lowest: compound 3; then compounds 1 and 4 (each within the scatter of the next). At a limit, above all of these: compound 2.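

Adding butoxy on the aromatic carbon, para to a large group, raises the number in this assay (a 2.9-fold higher number from compound 3 to compound 4 (0.46 log units; beyond the scatter)). This shows that hydrogen gives the lower number here against a chain that holds an oxygen atom as well as against butyl. Butoxy in place of butyl gives a 1.3-fold higher number from compound 1 to compound 4 (0.11 log units; within the scatter), so this assay does not separate the two chains. Butoxy in place of heptyl gives an at least 1.7-fold lower number from compound 2 to compound 4 (0.23 log units; that floor lies within the scatter). Compound 2 carries a limit and not a number, so this step can be read only as a floor: the limit of > 1000 nM in this assay, at which 1 of the 4 values shown sits.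

The compounds shown leave open how a shorter chain such as methoxy would read at this position. They also leave open whether an amine or a carboxylic acid there would give a number nearer to that of hydrogen.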